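Thiocarbonyl amine swap from compound 3 to compound 4

A few compounds are considered here, and "the series" means these few. Any claim that something is new, unique, unknown or untested is made for them only; others in the source may bear on it.

Going by the values given here, compound 3 `CN(C(=S)SCc1ccc(C(=O)Nc2ccccc2N)cc1)c1cccnc1` gives 87.7% in a functional assay on A-375 cells (Homo sapiens) for antiproliferative activity, read by CCK-8 assay, with a stated time of 72 h, tested at 8 uM (a higher number here means a stronger effect of the compound at the concentration tested, a lower number a weaker effect), the highest of the three numbers so far. Compound 2 `Nc1ccccc1NC(=O)c1ccc(CSC(=S)N2CCc3ccccc32)cc1` gives 85.4% in this assay, within the scatter of compound 3, while compound 1 `Nc1ccccc1NC(=O)c1ccc(CSC(=S)N2CCN(c3ccc(Cl)cc3)CC2)cc1` gives 29%, far lower. Among the compounds with values here, the only measured step at this position, a number 2.3 percentage points higher from compound 2 to compound 3 (within the scatter), stayed within the scatter. Compound 4 `Nc1ccccc1NC(=O)c1ccc(CSC(=S)N2CCCc3ccccc32)cc1` differs from compound 3 by 1,2,3,4-tetrahydroquinolin-1-yl in place of methyl(pyridin-3-yl)amino on a thiocarbonyl carbon. The entering group is close in kind to the 2,3-dihydro-1H-indol-1-yl of compound 2, so no step beyond the scatter is expected, because a number 2.3 percentage points higher from compound 2 to compound 3 (within the scatter) was itself within it. The expected step is a number 3.7 percentage points lower from compound 3 to compound 4 (within the scatter). Compound 4 is estimated at 84%, with a range from 68% to 95%.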

Compound 4, a percentage reported as inhibition, at one concentration (the size of the read-out at that concentration, not a potency): 81.5%
For compound 4 the middle estimate is 2.5 percentage points above the measured one; measured number inside the range.
By their numbers in this assay, from the lowest: compound 1; then compounds 4, 2 and 3 (each within the scatter of the next).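

In this assay the thiocarbonyl carbon now holds a third group at the same level, with a number 6.2 percentage points lower from compound 3 to compound 4 (within the scatter) and a number 3.9 percentage points lower from compound 2 to compound 4 (within the scatter). Methyl(pyridin-3-yl)amino, 2,3-dihydro-1H-indol-1-yl and 1,2,3,4-tetrahydroquinolin-1-yl are therefore not separated in this read-out, while compound 1 remains apart at 29%. No evidence is available that bears on this result.

Open, on these data alone, is whether a saturated amine without an aromatic ring, such as piperidine or morpholine, holds this level on the thiocarbonyl carbon.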